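The source may report more compounds than this note shows. Statements on the series, on what has been measured and on what is new or still open speak of the compounds shown alone.

Compounds measured in a functional assay, read by spectrophotometry, with a stated time of 15 min; on this read-out higher numbers stand for weaker inhibition and lower numbers for stronger inhibition: compound 1 `Cc1nc2c3ccccc3ccc2c2nc3c(ccc4ccccc43)c(-c3cccc([N+](=O)[O-])c3)c12` gives 54.2 ug/mL; compound 2 `Cc1nc2c3ccccc3ccc2c2nc3c(ccc4ccccc43)c(-c3nccnc3N)c12` gives 47.8 ug/mL; compound 3 `Cc1nc2c3ccccc3ccc2c2nc3c(ccc4ccccc43)c(-c3cccc4ccccc34)c12` gives 64.3 ug/mL.

On these numbers compound 3 gives the highest of the three, but its separation from the others is small: a 1.2-fold higher number from compound 1 to compound 3 (0.07 log units; within the scatter) and a 1.3-fold higher number from compound 2 to compound 3 (0.13 log units; within the scatter) both fall within the scatter. Compound 4 `Cc1nc2c3ccccc3ccc2c2nc3c(ccc4ccccc43)c(-c3ccccc3Cl)c12` arises from compound 3 by the change (2-chlorophenyl in place of naphthalen-1-yl on an aromatic carbon). Every measured exchange at this position bears on it, including a 1.1-fold lower number from compound 1 to compound 2 (0.05 log units; within the scatter), and none of them moved the number beyond the scatter. The step of a 1.2-fold lower number from compound 3 to compound 4 (0.07 log units; within the scatter) is therefore expected to be no larger than the scatter, with no direction favoured. In this assay compound 4 is estimated at 55 ug/mL, with a range from 30 ug/mL to 100 ug/mL.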

Compound 4, half-maximal inhibitory concentration: 74.6 ug/mL
Compound 4: the middle estimate sits 1.4-fold (0.13 log units) below what was measured, within the range that was stated.
By their numbers in this assay, from the lowest: compounds 2, 1, 3 and 4 (each within the scatter of the next).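

In this assay, the exchange of naphthalen-1-yl for 2-chlorophenyl, which leaves one six-membered aromatic ring of carbon only and brings in chlorine, stays within the scatter (a 1.2-fold higher number from compound 3 to compound 4 (0.06 log units; within the scatter)). The steps from the two other groups are also within the scatter (a 1.6-fold higher number from compound 2 to compound 4 (0.19 log units; within the scatter); a 1.4-fold higher number from compound 1 to compound 4 (0.14 log units; within the scatter)), so this position has now tolerated four different aromatic groups without a change that can be read. Nothing available explains this result. From the compounds shown here alone, whether an aliphatic amine, a carboxylic acid or a longer alkyl chain on this aromatic carbon would move the number remains open.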